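This account rests on a few compounds, and the source may have more. Where it says the series, first, only, none or still open, it means among the compounds named here.

Working notes on the series in an ADME assay on NIH3T3 cells (Mus musculus) for cytotoxicity, read by MTT assay; on this read-out lower numbers stand for stronger inhibition and higher numbers for weaker inhibition.

Three measured compounds share one core and differ only in the aryl group attached to it. Compound 1 `N#Cc1c(-c2ccc(O)cc2)c(C#N)c(=O)n(/N=C/c2cn(-c3ccccc3)nc2-c2ccccc2)c1N` gives 110 ug/mL in this assay. Compound 2 `N#Cc1c(-c2ccccc2Cl)c(C#N)c(=O)n(/N=C/c2cn(-c3ccccc3)nc2-c2ccccc2)c1N` gives 84 ug/mL, and compound 3 `Cc1ccc(-c2c(C#N)c(N)n(/N=C/c3cn(-c4ccccc4)nc3-c3ccccc3)c(=O)c2C#N)cc1` gives 98 ug/mL. Compound 3 thus stands second highest of the three numbers; the step of a 1.1-fold lower number from compound 1 to compound 3 (0.05 log units; within the scatter) and the step of a 1.2-fold higher number from compound 2 to compound 3 (0.07 log units; within the scatter) both lie within the scatter, as does a 1.3-fold lower number from compound 1 to compound 2 (0.12 log units; within the scatter), so the three aryl variants cannot be told apart on this read-out.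

Compound 4 `COc1ccc(-c2c(C#N)c(N)n(/N=C/c3cn(-c4ccccc4)nc3-c3ccccc3)c(=O)c2C#N)cc1` is the next member. Relative to compound 3 the change is methoxy in place of methyl on an aromatic carbon. Within the data shown here, no measured step reproduces this exact exchange; the step that bears on it most directly is a 1.1-fold lower number from compound 1 to compound 3 (0.05 log units; within the scatter), which also alters the group on the same aromatic carbon and is within the scatter, and the larger exchange a 1.2-fold higher number from compound 2 to compound 3 (0.07 log units; within the scatter) is equally flat. On that basis no step beyond the scatter is expected for compound 4, in either direction: a 1.0-fold higher number from compound 3 to compound 4 (0.01 log units; within the scatter).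

For compound 4 the expected value in this assay is therefore 100 ug/mL, with an estimated range from 55 ug/mL to 180 ug/mL.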

Compound 4, half-maximal inhibitory concentration: 50 ug/mL
Compound 4: the middle estimate sits 2.0-fold (0.30 log units) above what was measured, outside the stated range (below it).
By their numbers in this assay, from the lowest: compounds 4, 2, 3 and 1 (each within the scatter of the next, the first and the last beyond it).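

Among these compounds, at the aromatic carbon para to a large group, the earlier compounds gave only steps within the scatter, whereas compound 4 gives the first step beyond it in this assay (a 2.2-fold lower number from compound 1 to compound 4 (0.34 log units; beyond the scatter)), a modest change in which methyl replaces hydrogen on the oxygen of the hydroxy group. Methoxy in place of methyl at the same carbon remains within the scatter (a 2.0-fold lower number from compound 3 to compound 4 (0.29 log units; within the scatter)), as does 4-methoxyphenyl in place of 2-chlorophenyl (a 1.7-fold lower number from compound 2 to compound 4 (0.23 log units; within the scatter)), so only compound 1 is separated from compound 4, and the series shows no general effect of the aryl group on this read-out. Nothing available accounts for the modest step between the hydroxy and methoxy compounds, and it rests on this single pair.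

Still open, on these data alone, is whether a longer chain on the same oxygen, such as ethoxy, would extend the step seen with methoxy or leave the number within the scatter. It is equally open how an amine or a carboxylic acid at this aromatic carbon would read in this assay, since the compounds shown carry only hydroxy, methyl and methoxy there.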